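Carboxy to Carbamoylmethyl on a Thiazole Aniline Agonist

A few compounds are considered here, and "the series" means these few. Any claim that something is new, unique, unknown or untested is made for them only; others in the source may bear on it.

The two measured compounds share nothing but their aromatic acid tail and an arylamine linkage. Compound 1 `O=C(O)c1ccc(NCc2cccc(Oc3ccccc3)c2)cc1` carries a carboxy group directly on its ring, while compound 2 `Cc1nc(-c2ccc(C(F)(F)F)cc2)sc1CNc1ccc(CC(=O)O)cc1` bears a carboxymethyl chain on the aniline side of a substituted thiazole core. In a functional assay on CHO cells for agonist activity at Free fatty acid receptor 1 (Homo sapiens), read by a luciferase reporter (on this read-out lower numbers stand for smaller maximal responses and higher numbers for larger maximal responses), compound 1 gives 86%. In this assay compound 2 gives 18%, the lowest of the two numbers and beyond the scatter from compound 1.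

Compound 3 `Cc1nc(-c2ccc(C(F)(F)F)cc2)sc1CNc1ccc(CCC(N)=O)cc1` is the next step from compound 2. Going by the values given here, the change is carbamoylmethyl in place of carboxy on a saturated chain carbon bound to an aromatic carbon; no measured pair shows this change, so there is no step to lean on. The account therefore expects only a modest movement in this assay, without a clear direction beyond the scatter, given that compound 2 already sits at 18%. The expected step is a number 3 percentage points lower from compound 2 to compound 3 (within the scatter). For compound 3 the estimate is 15%, with a range from 5% to 35%.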

Compound 3, largest response reached (reported as percent of maximum), in percent of the reference or control that the assay uses: 88%
Estimate against measurement, compound 3: 73 percentage points below; the whole stated range lies below it.
By their numbers in this assay, from the lowest: compound 2; then compounds 1 and 3 (each within the scatter of the next).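

In this assay, putting carbamoylmethyl in place of carboxy on a saturated chain carbon bound to an aromatic carbon gives a number 70 percentage points higher from compound 2 to compound 3 (beyond the scatter), and this is the first pair shown that differs in only one place. On this core, the maximal response therefore depends strongly on the group at this place, and a carboxylic acid there is not required for a large response, since compound 3 reaches its response with an amide and no acid. No measurement shown bears on why the response moves so far.

The compounds shown do not separate the change of end group from the change of chain length, as the same difference also reads carboxymethyl to 2-carbamoylethyl; a 2-carboxyethyl chain, which keeps the acid on the longer chain, and a carbamoylmethyl chain, which keeps the amide on the shorter one, would tell these two apart. On these data alone, it also remains open whether the gain would survive on the longer chain with a methylamide, a nitrile or an alcohol as the end group.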